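The source may report more compounds than this note shows. Statements on the series, on what has been measured and on what is new or still open speak of the compounds shown alone.

Measured so far in an in vivo ADME assay on the whole organism (strain Sprague-Dawley) for pharmacokinetics, with Rattus norvegicus as the target; on this read-out lower numbers stand for lower oral bioavailability and higher numbers for higher oral bioavailability:
compound 1 `NCc1ccccc1-c1ccc(C(=O)N2N=C(c3cccnc3)CC2c2ccccc2O)s1`: 76%
compound 2 `O=C(c1ccc(-c2ccc3c(c2)CNC3)s1)N1N=C(c2cccnc2)CC1c1ccccc1O`: 14%

Compound 1 stands highest of the two numbers; its nearest neighbour is compound 2, which lies lower by a number 62 percentage points lower from compound 1 to compound 2 (beyond the scatter), a large step.

Compound 3 `NCc1ccccc1-c1ccc(C(=O)N2N=C(c3cccnc3)CC2c2c(O)cccc2F)s1` differs from compound 1 by fluoro in place of hydrogen on an aromatic carbon, which cut one bond further out reads 2-hydroxyphenyl to 2-fluoro-6-hydroxyphenyl. Among the measured compounds shown here, the one measured step, a number 62 percentage points lower from compound 1 to compound 2 (beyond the scatter), concerns a change at a different place of the shared core, an exchange of a whole aromatic group on the thiophene side, and does not touch the hydroxyphenyl part. For the measured compounds named here, it therefore gives no direct guide for the fluoro change; no measured pair varies the hydroxyphenyl ring. With the fluoro substituent entering as a single atom and the rest of compound 1 kept, the step in this assay is expected to stay within the usual scatter, the direction left open, with a wide range to reflect the missing comparison.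

The expected step from compound 1 to compound 3 is a number 8 percentage points lower from compound 1 to compound 3 (within the scatter). Compound 3 is thus estimated at 68%, ranging from 40% to 90%.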

Compound 3, oral bioavailability: 85%
Compound 3: the middle estimate sits 17 percentage points below what was measured; low and high end bracket the measured number.
By their numbers in this assay, from the lowest: compound 2; then compounds 1 and 3 (each within the scatter of the next).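

In this assay, the one change shown on the hydroxyphenyl part of the series, 2-hydroxyphenyl to 2-fluoro-6-hydroxyphenyl, gives a step (a number 9 percentage points higher from compound 1 to compound 3 (within the scatter)), so compound 3 and compound 1 cannot be told apart on this read-out. Fluoro in place of hydrogen is thus tolerated at this place, on an aromatic carbon ortho to a large group and meta to a hydroxy group, with oral bioavailability staying in the range of compound 1, whereas the earlier step (a number 62 percentage points lower from compound 1 to compound 2 (beyond the scatter)) concerned only the aromatic group on the thiophene side. No evidence is at hand that bears on this result.

From the compounds shown here alone, whether chloro, methoxy or trifluoromethyl at the same place would also stay in the range of compound 1 remains open, as does fluoro elsewhere on that ring. Also open, going by these compounds, is whether the same fluoro change would read the same with the group carried by compound 2, whose oral bioavailability lies far lower.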